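Swapping trifluoromethyl for tert-butyl on the aryl ether chain

The compounds below may be only part of what the source reports. "The series", "measured", "known", "first", "only" and "open" are said of these compounds alone.

Compound 1 `Nc1ccc2cccc(OCCC(F)(F)F)c2n1`: 722 nM
Compound 2 `Nc1ccc2cccc(OCC3CC4CCC3C4)c2n1`: 137 nM
Compound 3 `CC(CC(C)(C)C)Oc1cccc2ccc(N3CCCC3)nc12`: a limit only, > 2000 nM

In an assay on cells with melanin-concentrating hormone receptor 1 (Homo sapiens) as the target, read by radioligand binding (on this read-out lower numbers stand for stronger inhibition and higher numbers for weaker inhibition), compound 1 holds the higher of the two numbers that were read; compound 2 sits beyond the scatter below it. Compound 3 reached the limit of > 2000 nM in this assay, at which 1 of the 3 values shown sits, and gave no number.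

Compound 4 `CC(C)(C)CCOc1cccc2ccc(N)nc12` is the next step from compound 1: tert-butyl in place of trifluoromethyl on a saturated chain carbon, two bonds along the chain from an oxygen on an aromatic ring. Compound 2, which carries a saturated hydrocarbon group on the ether oxygen, gives 137 nM; on that ground a step toward lower numbers is expected for compound 4, of about a 3.3-fold lower number from compound 1 to compound 4 (0.52 log units; beyond the scatter). Compound 4 is therefore estimated at 220 nM. The expected range for compound 4 runs from 60 nM to 800 nM.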

Compound 4, half-maximal inhibitory concentration: 201 nM
Compound 4: the middle estimate sits 1.1-fold (0.04 log units) above what was measured; low and high end bracket the measured number.
By their numbers in this assay, from the lowest: compounds 2 and 4 (each within the scatter of the next); then compound 1. At a limit, above all of these: compound 3.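

In this assay, tert-butyl in place of trifluoromethyl gives a 3.6-fold lower number from compound 1 to compound 4 (0.56 log units; beyond the scatter), a modest step beyond the scatter. This is the first pair shown that differs in one place, so it isolates the end of the chain: on the shared core, an all-carbon end gives a lower number than the fluorinated one, with the heavy-atom count unchanged. Nothing measured here bears on why the number falls. From the compounds shown here alone, whether a hydroxyl, an amine or a carboxylic acid at this chain end, or a longer chain, would lower the number further remains open.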